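The compounds below may be only part of what the source reports. "The series", "measured", "known", "first", "only" and "open" are said of these compounds alone.

Of the compounds shown here, three have been tested in a functional assay on HCT-116 cells (Homo sapiens) for inhibition, read by MTT assay, with a stated time of 72 h, tested at 20 uM (a lower number here means less inhibition, a higher number more inhibition at the concentration tested (going by the name of the read-out)), and a fourth is about to be. Compound 1 `CN(c1ccc(Oc2ncnc3ccsc23)cc1)c1nccc(N2CCc3ccccc3C2)n1` gives 58.3% in this assay. Compound 3 `c1ccc2c(c1)CCN(c1ccnc(Nc3ccc(Oc4ncnc5ccsc45)cc3)n1)C2` is made from compound 1 by one change, (hydrogen in place of methyl on a nitrogen on an aromatic ring), and that change produced a number 17.4 percentage points lower from compound 1 to compound 3 (beyond the scatter). In this assay compound 3 gives 40.9%. Compound 2 `CN(c1ccc(Oc2ncnc3sccc23)cc1)c1nccc(N2CCCC2)n1` has a different core; how the two cores differ is not broken down here. In this assay compound 2 gives 42.2%, a number within the usual scatter of compound 3.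

Compound 4 `c1cc(N2CCCC2)nc(Nc2ccc(Oc3ncnc4sccc34)cc2)n1` has not yet been measured. Within the data shown here, it differs from compound 2 by hydrogen in place of methyl on a nitrogen on an aromatic ring, which is the same change, at the same kind of place, as the one that turned compound 1 into compound 3. Since that earlier change cost compound 1 a modest amount of inhibition, the expectation is that compound 2 loses a step of similar size, a number 16.2 percentage points lower from compound 2 to compound 4 (beyond the scatter), because the only shown instance of this change gave a number 17.4 percentage points lower from compound 1 to compound 3 (beyond the scatter). On that basis compound 4 is estimated at 26%, with a likely range from 10% to 42%, resting on a single prior step.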

Compound 4, a percentage reported as inhibition, at one concentration (the size of the read-out at that concentration, not a potency): 54.4%
Estimate against measurement, compound 4: 28.4 percentage points below, and the stated range ends below it.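

On the core of compound 2, swapping the methyl on this nitrogen for hydrogen gave a number 12.2 percentage points higher from compound 2 to compound 4 (beyond the scatter) in this assay, so the same swap that lowered the number on the core of compound 1 raised it here. Set side by side, the two steps do not agree, and even their direction differs: the same change on two cores in this assay, a number 17.4 percentage points lower (beyond the scatter) from compound 1 to compound 3 and a number 12.2 percentage points higher (beyond the scatter) from compound 2 to compound 4, 29.6 percentage points apart, beyond the scatter of two such steps This shows that the effect of this change cannot simply be carried from one core to another in this series, but it does not show what turns the step around, since there is only one pair for each core and compound 1 and compound 2 differ in more than one place.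

The compounds shown carry only methyl or hydrogen on this nitrogen, so it remains open how an ethyl group or a longer chain there would behave on either core. As far as these compounds go, it also remains open which part of the structure decides the direction of the step, and whether further pairs on these cores would repeat it.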